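Isopropyl on the Ring Amide Nitrogen of Compound 1

This account rests on a few compounds, and the source may have more. Where it says the series, first, only, none or still open, it means among the compounds named here.

For the measured compounds named here, compound 1 `COc1ncc(-c2ccc3c(c2)NC(=O)CO3)cc1NS(=O)(=O)c1ccc(F)cc1` is the only compound here that returns a number rather than a limit: in a functional assay on MCF7 cells (Homo sapiens) for antiproliferative activity, read by MTT assay, with a stated time of 72 h (on this read-out lower numbers stand for stronger inhibition and higher numbers for weaker inhibition), compound 1 gives 32300 nM. Compound 2 `O=C1COc2ccc(-c3cnc(Cl)c(NS(=O)(=O)c4ccc(F)cc4)c3)cc2N1` carries chloro in place of methoxy on an aromatic carbon, and in this assay compound 2 reaches only the limit of the measurement, > 40000 nM. The resulting step, an at least 1.2-fold higher number from compound 1 to compound 2 (0.09 log units; that floor lies within the scatter), cannot be sized beyond that floor (the limit of > 40000 nM in this assay, at which 2 of the 3 values shown sit). Compound 3 `O=C1COc2ccc(-c3cccc(NS(=O)(=O)c4ccc(F)cc4)c3)cc2N1C1CC1` differs from compound 1 in more than one place, and in this assay compound 3 also returns only a limit, > 40000 nM.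

Compound 4 `COc1ncc(-c2ccc3c(c2)N(C(C)C)C(=O)CO3)cc1NS(=O)(=O)c1ccc(F)cc1` is the untested one. Its change from compound 1 is isopropyl in place of hydrogen on an amide-type nitrogen in a ring. Going by the values given here, none of the measured steps alters the amide-type nitrogen in a ring on its own, so there is no direct guide for this change. Compound 1 gives a weak number, 32300 nM. Most of the other values sit at the floor of the measurement (the limit of > 40000 nM in this assay, at which 2 of the 3 values shown sit), so the expected step of a 1.2-fold higher number from compound 1 to compound 4 (0.07 log units; within the scatter) is small and no move beyond the scatter is expected in this assay. The estimate for compound 4 is 38000 nM, within 15000 nM to 100000 nM, with a real chance that only a limit is reported.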

Compound 4, half-maximal inhibitory concentration: 17000 nM
Compound 4: middle estimate off by 2.2-fold (0.35 log units), on the high side; the measured number falls inside the stated range.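

In this assay, for the compounds shown here, this is the first change made on the amide-type nitrogen alone, and it reads as a 1.9-fold lower number from compound 1 to compound 4 (0.28 log units; within the scatter). Putting isopropyl in place of the amide hydrogen therefore leaves the reading where it was within normal assay variation, and compound 4 still returns a real number, so in this pair the amide hydrogen is not needed for the weak antiproliferative effect seen on these cells. The result is only a modest guide to this position, since both compounds of the pair are weak and compound 2 and compound 3 are reported only as a limit: the limit of > 40000 nM in this assay, at which 2 of the 4 values shown sit.

From the compounds shown here alone, what remains open is whether any group on this nitrogen can move the reading beyond the usual scatter, for instance a longer chain ending in an amine or a carboxylic acid, as isopropyl is the only replacement for the hydrogen that can be read here on its own. Going by these compounds, it is also open whether isopropyl on this nitrogen would behave the same way with chloro in place of methoxy on the aromatic carbon, as in compound 2.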